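Amino for methoxy on the aniline ring: an estimate

The compounds below may be only part of what the source reports. "The series", "measured", "known", "first", "only" and "open" are said of these compounds alone.

Measured in a functional assay on PC-3 cells (Homo sapiens) for cytotoxicity, read by MTT assay, with a stated time of 72 h; a higher number here means a weaker inhibitor, a lower number a stronger inhibitor:
- compound 1, `COc1ccc(Nc2nc3ccccc3nc2S(=O)(=O)c2ccccc2)cc1`, gives 1510 nM
- compound 2, `COc1cc(Nc2nc3ccccc3nc2S(=O)(=O)c2ccccc2)cc(OC)c1OC`, gives 29100 nM
- compound 3, `Nc1ccc(Nc2nc3ccccc3nc2S(=O)(=O)c2ccccc2)cc1`, gives 5830 nM

Among these three, compound 1 has the lowest number in this assay; compound 3 is its nearest neighbour and compound 2 its furthest, both beyond the scatter. The new compound is compound 4, `Nc1cccc(Nc2nc3ccccc3nc2S(=O)(=O)c2ccccc2)c1`. It differs from compound 1 by 3-aminophenyl in place of 4-methoxyphenyl on a nitrogen on an aromatic ring.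

Among the measured compounds shown here, one measured step bears on this change: a 3.9-fold higher number from compound 1 to compound 3 (0.59 log units; beyond the scatter), where an amino group replaces the methoxy group on the aniline ring. Compound 4 makes the same exchange of amino for methoxy, so a modest weakening of similar size is expected in this assay, with the caveat that compound 3 and compound 4 place the amino group on different carbons and no measurement tells how much that matters. Compound 4 is therefore estimated at 6000 nM, with a likely range from 2000 nM to 20000 nM, which is an expected step of a 4.0-fold higher number from compound 1 to compound 4 (0.60 log units; beyond the scatter).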

Compound 4, half-maximal inhibitory concentration: 2150 nM
The estimate for compound 4 lay 2.8-fold (0.45 log units) above the measured number, and the stated range covers the measured number.
By their numbers in this assay, from the lowest: compounds 1 and 4 (each within the scatter of the next); then compound 3; then compound 2.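

In this assay, 3-aminophenyl in place of 4-aminophenyl gives a 2.7-fold lower number from compound 3 to compound 4 (0.43 log units; beyond the scatter) and so shows that the place of the amino group on this ring matters, which compound 3 alone could not reveal. With 3-aminophenyl in place of 4-methoxyphenyl there is a 1.4-fold higher number from compound 1 to compound 4 (0.15 log units; within the scatter) and no real separation, so the weakening seen with compound 3 does not follow from having an amino group on this ring, as compound 4 carries one too. Nothing available gives a reason for either step.

From the compounds shown here alone, whether a methoxy group moved in the same way would shift the number likewise stays open. So does what a hydroxyl group or a carboxylic acid would do in the place of the amino group of compound 4.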